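This account rests on a few compounds, and the source may have more. Where it says the series, first, only, none or still open, it means among the compounds named here.

Compound 1 `O=C(/N=C1\NC2(CCCCO2)CCS1)c1ccccc1` gives 5 mg/kg in a functional assay on the whole organism (strain CF-1) with Mus musculus as the target, in the writhing test, with a stated time of 15 min; a higher number here means that more compound is needed for the effect, a lower number that less compound is needed.
Compound 2 `COc1ccc(C(=O)/N=C2\NC3(CCCCO3)CCS2)cc1` gives 62 mg/kg in this assay.

Compound 1 holds the lower of the two numbers; compound 2 stands apart from it by a 12-fold higher number from compound 1 to compound 2 (1.09 log units; beyond the scatter). Compound 3 `O=C(/N=C1\NC2(CCCCO2)CCS1)c1ccccc1Cl` differs from compound 1 by chloro in place of hydrogen on an aromatic carbon. Among the compounds with values here, the single measured step, a 12-fold higher number from compound 1 to compound 2 (1.09 log units; beyond the scatter), concerns another group at another place and so bears on this change only loosely; it shows that a substituent on that ring can raise the number markedly. A higher number in this assay is therefore expected for compound 3, though smaller than that step and with wide uncertainty. The expected step is a 2.0-fold higher number from compound 1 to compound 3 (0.30 log units; within the scatter). Compound 3 is estimated at 10 mg/kg, within 3 mg/kg to 40 mg/kg.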

Compound 3, dose for half-maximal effect: > 200 mg/kg
Compound 3 was reported as a limit; the forecaster's own chance of this, stated with the estimate: 5%; at least 20-fold (1.30 log units) between middle value and limit.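

Compound 3 is reported only as a limit in this assay: the limit of > 200 mg/kg in this assay, at which 1 of the 3 values shown sits. On an aromatic carbon ortho to a large group, the change from phenyl to 2-chlorophenyl, with a single added heavy atom, gives an at least 40-fold higher number from compound 1 to compound 3 (1.60 log units; beyond the scatter). Among the three compounds, both ring substituents raise the number, and none lowers it below that of compound 1.

The compounds shown do not separate the effect of chloro from that of this place on the ring. As far as these compounds go, what fluoro, methyl or an amine would give at this place remains open, as does chloro elsewhere on the ring.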